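Moving the Methyl on the Amide Aryl Group

The compounds below may be only part of what the source reports. "The series", "measured", "known", "first", "only" and "open" are said of these compounds alone.

Compound 1 `COc1ccc2c(=O)c(/C=C/C(=O)Nc3ccc(C)cc3)coc2c1` is the starting point of this account. In a functional assay on L02 cells (Homo sapiens) for inhibition, read by MTT assay, with a stated time of 48 h (on this read-out higher numbers stand for weaker inhibition and lower numbers for stronger inhibition), compound 1 returns only a limit, > 200000 nM, so no number stands for it. Two related compounds are known in the same way. Compound 2 `Cc1ccccc1NC(=O)/C=C/c1coc2cc(O)ccc2c1=O` gives in this assay only the limit > 200000 nM. Compound 3 `COc1ccc(CNC(=O)/C=C/c2coc3cc(OC)ccc3c2=O)cc1` gives in this assay only the limit > 200000 nM. For the measured compounds named here, the one step that can be named, a step that the two limits leave unreadable from compound 1 to compound 3, cannot be read in size, because the limit of > 200000 nM in this assay, at which 3 of the 3 values shown sit, holds every value shown.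

Compound 4 `COc1ccc2c(=O)c(/C=C/C(=O)Nc3ccccc3C)coc2c1` is the unmeasured compound. It differs from compound 1 as follows: 2-methylphenyl in place of 4-methylphenyl on an amide-type nitrogen. Going by the values given here, no measured step bears directly on this change; the closest hint is compound 2, which also carries a 2-methylphenyl on its amide nitrogen and sits at the limit. Compound 4 is therefore expected to stay at the limit in this assay, with a step that the limit leaves unreadable from compound 1 to compound 4 of no readable size. The estimate for compound 4 is 400000 nM, within 150000 nM to 1500000 nM.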

Compound 4, half-maximal inhibitory concentration: > 200000 nM
Compound 4 was reported as a limit (the forecaster's own chance of this, stated with the estimate: 85%); the middle value is on the limit's open side.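

Compound 4 is reported only as a limit, so none of its steps to compound 1, compound 2 or compound 3 can be read in size: the limit of > 200000 nM in this assay, at which 4 of the 4 values shown sit.

The compounds shown leave open whether 2-methylphenyl and 4-methylphenyl on the amide nitrogen differ at all in this assay.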